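Weak series in the cytotoxicity assay; aminophenyl variant of compound 3

The compounds below may be only part of what the source reports. "The series", "measured", "known", "first", "only" and "open" are said of these compounds alone.

Compound 1 `Fc1cccc(-c2nc(Nc3ccccc3)c3cc(F)ccc3n2)c1` is the parent of the set. Among the compounds with values here, in a functional assay on HT29-AK cells (Homo sapiens) for cytotoxicity, read by MTT assay, with a stated time of 48 h (a higher number here means a weaker inhibitor, a lower number a stronger inhibitor), compound 1 gives 48300 nM, the only value of the three that is a number. Compound 2 `Fc1cccc(-c2nc(Nc3cccc(Br)c3)c3cc(F)ccc3n2)c1` carries bromo in place of hydrogen on an aromatic carbon; in this assay compound 2 reaches only the limit > 50000 nM. Compound 3 `Oc1ccccc1Nc1nc(-c2cccc(F)c2)nc2ccc(F)cc12` carries hydroxy in place of hydrogen on an aromatic carbon; in this assay compound 3 likewise reaches only the limit > 50000 nM. So compound 3 stands at the limit rather than at a number, as does one other value of the set (the limit of > 50000 nM in this assay, at which 2 of the 3 values shown sit). The steps were an at least 1.0-fold higher number from compound 1 to compound 2 (0.01 log units; that floor lies within the scatter) and an at least 1.0-fold higher number from compound 1 to compound 3 (0.01 log units; that floor lies within the scatter), and a step that the two limits leave unreadable from compound 2 to compound 3.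

Compound 4 `Nc1cccc(Nc2nc(-c3cccc(F)c3)nc3ccc(F)cc23)c1` differs from compound 3 by 3-aminophenyl in place of 2-hydroxyphenyl on a nitrogen on an aromatic ring. Within the data shown here, no measured step bears directly on this exchange; the steps from compound 1 show no change beyond the scatter, and compound 3 sits at the limit. For compound 4 no step beyond the scatter is therefore expected, a step that the limit leaves unreadable from compound 3 to compound 4, with a high chance of another limit. Compound 4 is estimated at 60000 nM, within 30000 nM to 150000 nM.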

Compound 4, half-maximal inhibitory concentration: > 50000 nM
Compound 4: only a limit was reported (the forecaster's own chance of this, stated with the estimate: 70%); the middle value lies beyond the limit too.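

In this assay compound 4 also gives only a limit, > 50000 nM, so amino joins bromo and hydroxy as a third replacement of hydrogen on the anilino-free parent ring that yields no number. Within the data shown here, the one readable step is an at least 1.0-fold higher number from compound 1 to compound 4 (0.01 log units; that floor lies within the scatter), and it shows no change beyond the scatter. The steps from compound 2 and from compound 3 to compound 4 cannot be read, since both ends are limits, and the set now gathers at one ceiling: the limit of > 50000 nM in this assay, at which 3 of the 4 values shown sit.

On these data alone, how far compound 2, compound 3 and compound 4 lie past that limit remains unknown. Also open, as far as these compounds go, is whether a different group on this ring, such as a carboxylic acid or a methoxy group, would give a value that can be read in this assay.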